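A few compounds are considered here, and "the series" means these few. Any claim that something is new, unique, unknown or untested is made for them only; others in the source may bear on it.

The series shares a core carrying a thiosemicarbazide link to a phenylthiophene; it is tested in a functional assay on U-373MG ATCC cells (Homo sapiens) for inhibition, read by colorimetric assay and MTT assay, with a stated time of 72 h; on this read-out higher numbers stand for weaker inhibition and lower numbers for stronger inhibition. Compound 1 `COc1cc(C(=O)NNC(=S)Nc2csc(-c3ccccc3)c2)cc(OC)c1OC` gives 44000 nM in this assay, the lower of the two numbers shown, though it lies within the scatter of compound 2 `COc1cc(C(=O)NNC(=S)Nc2csc(-c3ccc(C)cc3)c2)cc(OC)c1OC`, which gives 47000 nM. The step of a 1.1-fold higher number from compound 1 to compound 2 (0.03 log units; within the scatter) shows that a methyl in place of hydrogen on the aromatic carbon makes no difference beyond the scatter. Compound 3 `O=C(NNC(=S)Nc1csc(-c2ccccc2)c1)c1ccc(O)cc1` reaches only the limit of the assay, > 100000 nM; this is recorded in the limit of > 100000 nM in this assay, at which 1 of the 3 values shown sits.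

Compound 4 `COc1cc(OC)cc(C(=O)NNC(=S)Nc2csc(-c3ccccc3)c2)c1` follows from compound 1 by the change hydrogen in place of methoxy on an aromatic carbon, ortho to two methoxy groups and para to a large group. For the measured compounds named here, no measured step removes a methoxy from this ring, so none bears directly on it; the one measured step, from compound 1 to compound 2, concerns a different ring and is within the scatter, while compound 3, which lacks methoxy altogether, gives only a limit. A modest weakening of inhibition is therefore expected, so that compound 4 is estimated at 65000 nM (range 25000 nM to 160000 nM), a step of a 1.5-fold higher number from compound 1 to compound 4 (0.17 log units; within the scatter) in this assay.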

Compound 4, half-maximal inhibitory concentration: 40000 nM
Beside the measured number, compound 4's estimate is 1.6-fold (0.21 log units) above it; measured number inside the range.
By their numbers in this assay, from the lowest: compounds 4, 1 and 2 (each within the scatter of the next). At a limit, above all of these: compound 3.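

In this assay, the methoxy group that stands para to a large group and ortho to two methoxy groups gives way to hydrogen with no change beyond the scatter: a 1.1-fold lower number from compound 1 to compound 4 (0.04 log units; within the scatter). For the compounds shown here, this is the first measured step on the methoxy-bearing ring, the earlier step having concerned the other aromatic ring, and it shows that this methoxy group is not needed for the level of inhibition seen with compound 1, weak as that level is on this read-out. Nothing among the data shown gives a reason for this flat result.

As far as these compounds go, whether the position tolerates other replacements, such as an amine, a carboxylic acid or a longer chain in place of the methoxy group, remains open, as does the effect of changing the two methoxy groups that remain in compound 4. Compound 3 stands at a limit of the assay, > 100000 nM, and differs from compound 1 in more than one place, so it does not settle what those remaining groups contribute.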